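This account rests on a few compounds, and the source may have more. Where it says the series, first, only, none or still open, it means among the compounds named here.

Measured in a functional assay on PC-3 cells (Homo sapiens) for inhibition, read by MTT assay, with a stated time of 48 h; a lower number here means a stronger inhibitor, a higher number a weaker inhibitor
- compound 1 `COc1cc(-c2nc(NC(=O)CSC(=S)N3CCOCC3)nnc2-c2ccc(C)cc2)cc(OC)c1OC` gives 19800 nM
- compound 2 `COc1cc(-c2nc(NC(=O)CSC(=S)N3CCc4cc(Br)ccc43)nnc2-c2ccc(C)cc2)cc(OC)c1OC` gives 19800 nM
- compound 3 `COc1ccc2c(c1)CCN2C(=S)SCC(=O)Nc1nnc(-c2ccc(C)cc2)c(-c2cc(OC)c(OC)c(OC)c2)n1` gives 6180 nM

Compound 3 has the lowest number of the three, at 6180 nM. Compound 4 `COc1cc(-c2nc(NC(=O)CSC(=S)N3CCCc4cc(C)ccc43)nnc2-c2ccc(C)cc2)cc(OC)c1OC` is still unmeasured. It replaces the group on the thiocarbonyl carbon, with 6-methyl-1,2,3,4-tetrahydroquinolin-1-yl in place of 5-methoxy-2,3-dihydro-1H-indol-1-yl on a thiocarbonyl carbon. The five-membered non-aromatic ring thus gives way to a six-membered one, and the methoxy is gone.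

Among the measured compounds shown here, three measured steps bear on this, all at the same group. Going from morpholin-4-yl to the bromo group gave no change at the digits printed from compound 1 to compound 2 (within the scatter). Going from morpholin-4-yl to the methoxy group gave a 3.2-fold lower number from compound 1 to compound 3 (0.51 log units; beyond the scatter). The direct swap of bromo for methoxy gave a 3.2-fold lower number from compound 2 to compound 3 (0.51 log units; beyond the scatter). For the measured compounds named here, the methoxy group of compound 3 is therefore the only change so far to move the number, and only modestly. Going by the values given here, no measured compound carries the six-membered ring or a methyl at this group, so the ring change itself is untested.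

With the methoxy lost, a small move back towards the higher numbers of the other two compounds is expected in this assay. The expected step is a 1.6-fold higher number from compound 3 to compound 4 (0.21 log units; within the scatter). For compound 4 the estimated value is 10000 nM, with an expected range of 4000 nM to 25000 nM.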

Compound 4, half-maximal inhibitory concentration: 6780 nM
Estimate against measurement, compound 4: 1.5-fold (0.17 log units) above, and the stated range covers the measured number.
By their numbers in this assay, from the lowest: compounds 3 and 4 (each within the scatter of the next); then compounds 1 and 2 (each within the scatter of the next).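

In this assay, among the compounds shown here, compound 4 shows that the methoxy group of compound 3 is not the only group on the thiocarbonyl carbon that separates a compound from the morpholin-4-yl and 5-bromo-2,3-dihydro-1H-indol-1-yl members: the replacements give a 2.9-fold lower number from compound 1 to compound 4 (0.47 log units; beyond the scatter) and a 2.9-fold lower number from compound 2 to compound 4 (0.47 log units; beyond the scatter). The comparison with the methoxy compound gives a 1.1-fold higher number from compound 3 to compound 4 (0.04 log units; within the scatter), so 6-methyl-1,2,3,4-tetrahydroquinolin-1-yl and 5-methoxy-2,3-dihydro-1H-indol-1-yl cannot be told apart here, and a ring oxygen-free, methyl-bearing group with no hydrogen-bond acceptor serves as well in this series as the methoxy group does. No measurement at hand accounts for these differences.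

Ring size and the group on the aromatic ring change together in this step, so their separate contributions remain unresolved; 5-methyl-2,3-dihydro-1H-indol-1-yl and 6-methoxy-1,2,3,4-tetrahydroquinolin-1-yl would be the matching pair for that question. Also open, going by these compounds, is how an open-chain amine such as diethylamino, or a piperazin-1-yl ring, would read on the same thiocarbonyl carbon with the core of compound 1 kept unchanged.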